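A Cyclopropyl Gives Way to a Pyrazole

The source may report more compounds than this note shows. Statements on the series, on what has been measured and on what is new or still open speak of the compounds shown alone.

Compound 1 `O=C(NCc1cc(Cl)ccc1-n1cnnn1)[C@@H]1[C@H]2C[C@H]2CN1C(=O)[C@H](O)CC1CC1` was tested in a functional assay on a cell-free system (plasma, Homo sapiens), with a stated time of 3 min (on this read-out lower numbers stand for stronger inhibition and higher numbers for weaker inhibition), where compound 1 gives 1400 nM. Two companions share its core. Compound 2 `Cc1cccc([C@@H](O)C(=O)N2N=CC[C@H]2C(=O)NCc2cc(Cl)ccc2-n2cnnn2)c1` gives 830 nM in this assay, and compound 3 `O=C([C@H](O)c1ccccc1)N1CC[C@@H]2C[C@@]21C(=O)NCc1cc(Cl)ccc1-n1cnnn1` gives 1100 nM. Of the three numbers, that of compound 1 is the highest, yet its gaps to compound 3 and to compound 2 both lie within the usual scatter of repeated measurements, so no order among the three can be read from these values.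

Compound 4 `O=C(NCc1cc(Cl)ccc1-n1cnnn1)[C@@H]1[C@H]2C[C@H]2CN1C(=O)[C@H](O)Cn1cccn1` has not been measured yet. It differs from compound 1 in one place: 1H-pyrazol-1-yl in place of cyclopropyl on a saturated chain carbon, two bonds along the chain from a carbonyl carbon and an oxygen on a saturated carbon. Among the compounds with values here, no pair of measured compounds shows this same change, so the size of the step has to be estimated without a direct precedent. Only a modest shift is expected, most likely towards a somewhat lower number for compound 4. In this assay compound 4 is estimated at 900 nM, with an expected range from 300 nM to 3000 nM. The step expected is a 1.6-fold lower number from compound 1 to compound 4 (0.19 log units; within the scatter).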

Compound 4, half-maximal inhibitory concentration: 1800 nM
For compound 4 the middle estimate is 2.0-fold (0.30 log units) below the measured one; the range from low to high includes it.
By their numbers in this assay, from the lowest: compounds 2, 3, 1 and 4 (each within the scatter of the next, the first and the last beyond it).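

Within the data shown here, this is the first direct comparison at this position: in this assay, placing 1H-pyrazol-1-yl where cyclopropyl stood gives a 1.3-fold higher number from compound 1 to compound 4 (0.11 log units; within the scatter). The entering group has 5 heavy atoms against 3 and brings 2 hydrogen-bond acceptors where the leaving group has 0, yet the read-out shows no change beyond the scatter, so on this core the swap from a three-membered carbon ring to a five-membered aromatic ring leaves inhibition effectively unchanged. No measurement shown here offers an explanation for this result.

With only these two groups compared on this core, the compounds shown do not reveal how far this position accepts other groups. An amine, a carboxylic acid or a longer chain in this place remains an open case, as does the same swap on a different core.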